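This account rests on a few compounds, and the source may have more. Where it says the series, first, only, none or still open, it means among the compounds named here.

Compound 1 `O=S(=O)(NCCCNCc1cccc(Cl)c1)c1cc(C(F)(F)F)cc(C(F)(F)F)c1` gives 6900 nM in a functional assay on BE(2)-C cells (Homo sapiens) for inhibition, read by MTT assay, with a stated time of 72 h; on this read-out lower numbers stand for stronger inhibition of growth and higher numbers for weaker inhibition of growth.
Compound 2 `O=S(=O)(NCCCNCC1COc2ccccc2O1)c1cc(C(F)(F)F)cc(C(F)(F)F)c1` gives 2800 nM in this assay.
Compound 3 `O=S(=O)(NCCCNCc1ccccc1)c1cc(C(F)(F)F)cc(C(F)(F)F)c1` gives 12000 nM in this assay.

Among these three, compound 3 carries the highest number. Its nearest neighbour is compound 1, separated by a 1.7-fold higher number from compound 1 to compound 3 (0.24 log units; within the scatter), a gap within the scatter; compound 2 lies furthest away, separated by a 4.3-fold higher number from compound 2 to compound 3 (0.63 log units; beyond the scatter), a gap beyond the scatter.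

Compound 4 `O=S(=O)(NCCCNCc1ccc(Br)cc1)c1cc(C(F)(F)F)cc(C(F)(F)F)c1` differs from compound 3 by bromo in place of hydrogen on an aromatic carbon. Going by the values given here, only one measured step concerns a halogen on this ring: a 1.7-fold higher number from compound 1 to compound 3 (0.24 log units; within the scatter), in which a chloro was replaced by hydrogen and the number stayed within the scatter. Among the compounds with values here, no compound carrying bromo, or a group para to a large group, has been measured in this assay. Within the data shown here, since the one halogen step seen so far was small, the step for compound 4 is expected to be small as well, pointing toward a somewhat lower number that most likely stays within the scatter: a 1.5-fold lower number from compound 3 to compound 4 (0.18 log units; within the scatter). Compound 4 is therefore estimated at 8000 nM, with a range from 3500 nM to 20000 nM.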

Compound 4, concentration for 50% growth inhibition: 2700 nM
Estimate against measurement, compound 4: 3.0-fold (0.47 log units) above; measured number outside the range, below it.
By their numbers in this assay, from the lowest: compounds 4 and 2 (each within the scatter of the next); then compounds 1 and 3 (each within the scatter of the next).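

A bromo on this ring, at the place para to a large group, counts for more than the earlier halogen step suggested: a 4.4-fold lower number from compound 3 to compound 4 (0.65 log units; beyond the scatter) in this assay lies beyond the scatter, while a 1.7-fold higher number from compound 1 to compound 3 (0.24 log units; within the scatter) stayed within it. The step to the other halogenated compound is also beyond the scatter at a 2.6-fold lower number from compound 1 to compound 4 (0.41 log units; beyond the scatter), and 4-bromophenyl stands level with the fused oxygen-bearing group of compound 2 in a 1.0-fold lower number from compound 2 to compound 4 (0.02 log units; within the scatter), so a single bromo matches that larger group here. No evidence at hand explains these steps.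

The compounds shown leave open whether the gain follows the bromine itself or its place, as 4-chlorophenyl and 3-bromophenyl are not among them. From the compounds shown here alone, how a 4-methoxyphenyl group or a longer chain between the two nitrogens would fare also remains open.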